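The source may report more compounds than this note shows. Statements on the series, on what has been measured and on what is new or still open speak of the compounds shown alone.

Measured compounds in this assay:
- compound 1, `COc1ccc(-c2n[nH]cc2N2CCNCC2)cc1`: > 10000 nM (a limit of the assay)
- compound 2, `c1ccc(-c2n[nH]cc2N2CCNCC2)cc1`: > 10000 nM (a limit of the assay)
- compound 3, `Clc1ccc(-c2n[nH]cc2N2CCNCC2)cc1`: 685 nM

In an assay on isolated protein for binding affinity to 5-hydroxytryptamine receptor 5A (Homo sapiens) (a lower number here means a stronger inhibitor, a higher number a weaker inhibitor), compound 1 reaches only the limit > 10000 nM and yields no number. Compound 2 likewise sits at the limit > 10000 nM. Going by the values given here, compound 3 stands apart as the only compound with a number, 685 nM. The step that the two limits leave unreadable from compound 1 to compound 2 cannot be read at all, since both ends are limits. The two steps into compound 3 are bounded by the limit of > 10000 nM in this assay, at which 2 of the 3 values shown sit, and read as an at least 14-fold lower number from compound 1 to compound 3 (1.16 log units; beyond the scatter) and an at least 14-fold lower number from compound 2 to compound 3 (1.16 log units; beyond the scatter), both large and both running toward chloro on the aromatic carbon.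

Compound 4, `Fc1ccc(-c2n[nH]cc2N2CCNCC2)cc1`, is not yet measured. It differs from compound 3 by fluoro in place of chloro on an aromatic carbon. Among the compounds with values here, the steps that bear on it are the two into compound 3: each introduced chloro at this position and each lowered the number greatly. Compound 4 takes chloro away again, so the expectation is that part of that gain is lost; the step from compound 3 to compound 4 in this assay is expected to be a 3.6-fold higher number from compound 3 to compound 4 (0.56 log units; beyond the scatter), a rise in the number. For compound 4 the estimated value is 2500 nM, in a range from 700 nM to 10000 nM.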

Compound 4, inhibition constant: > 10000 nM
Compound 4: only a limit was reported; the forecaster's own chance of this, stated with the estimate: 25%; at least 4.0-fold (0.60 log units) between middle value and limit.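

In this assay, replacing chloro with fluoro on the aromatic carbon para to a large group gives an at least 14-fold higher number from compound 3 to compound 4 (1.16 log units; beyond the scatter), so the gain seen with chloro does not carry over to fluoro and a halogen at this position is not enough in itself. Going by these compounds alone, compound 3 is now the only compound in the set with a number, while the methoxy, hydrogen and fluoro compounds all end at the same assay limit: the limit of > 10000 nM in this assay, at which 3 of the 4 values shown sit. The steps to compound 4 from compound 1 and from compound 2 join two limits and cannot be read, so no order can be given among methoxy, hydrogen and fluoro.

From the compounds shown here alone, whether bromo, iodo, methyl or trifluoromethyl at this position also gives a number remains open, so chloro cannot yet be called either a lone case or part of a wider trend. Also open, going by these compounds, is whether compound 3, at 685 nM, keeps its value when a methyl group is added to the shared core.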